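A few compounds are considered here, and "the series" means these few. Any claim that something is new, unique, unknown or untested is made for them only; others in the source may bear on it.

Compound 1, `N#C/N=C(/NCCCCc1c[nH]cn1)NCCCc1cccnc1`, gives 5.92 in an in vitro functional assay on Sf9 cells for antagonist activity at histamine H2 receptor (Homo sapiens); on this read-out higher numbers stand for higher potency (the scale is a negative logarithm) and lower numbers for lower potency.
Compound 2, `CC(C)N/C(=N\C#N)NCCCCc1c[nH]cn1`, gives < 5 in this assay.

Where compound 2 stands: its reading of < 5 in this assay is a limit of the measurement, not a number. This is the case described by the limit of < 5 in this assay, at which 1 of the 2 values shown sits. Compound 3, `CC(C)CN/C(=N\C#N)NCCCCc1c[nH]cn1`, differs from compound 2 in one place: isobutyl in place of isopropyl on an amine nitrogen. The rest of the molecule, the shared core with its cyanoguanidine chain, is unchanged. Among the compounds with values here, no pair of measured compounds here differs by such a step, so there is nothing measured to lean on; the change is a small alkyl group exchanged for another small alkyl group. The step is expected to be a number no lower from compound 2 to compound 3 (the limit leaves the size open), within the usual scatter and in no clear direction. Compound 3 is therefore estimated at 5, with a range from 4.5 to 5.6, and it may well again return only a limit.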

Compound 3, negative logarithm of the antagonist equilibrium constant: < 5
Compound 3 gave a limit, no number; the forecaster's own chance of this, stated with the estimate: 55%; the middle value sits exactly at the limit.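

In this assay compound 3 gives < 5, which is a limit of the measurement and not a number. Compound 2 also gave only a limit, so the step between them cannot be read, and exchanging isopropyl for isobutyl on this amine nitrogen yields no measurable reading: the limit of < 5 in this assay, at which 2 of the 3 values shown sit.

The one readable comparison puts the small isobutyl group in place of the longer ring-bearing chain of the other compound and gives a number at least 0.92 log units lower from compound 1 to compound 3 (beyond the scatter), so among the compounds shown only the ring-bearing chain gives a reading above the limit.

As far as these compounds go, whether the ring or simply the length of that chain matters stays open, and a plain longer alkyl chain or a phenyl ring on the same chain could separate the two. From the compounds shown here alone, how far compound 2 and compound 3 lie under their limits also stays open.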